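The compounds below may be only part of what the source reports. "The series", "measured", "known", "first", "only" and "open" are said of these compounds alone.

Going by the values given here, compound 2, with the structure `CCOC(=O)OCOC(=O)C1=C(S[C@@H]2CN[C@H](C(=O)Nc3cccc(C(=O)O)c3)C2)[C@H](C)[C@@H]2[C@@H]([C@@H](C)O)C(=O)N12`, is one of two compounds measured in an ADME assay for metabolic stability, read by LC-MS, with a stated time of 3 h, at pH 6.5, tested at 50 uM; a higher number here means that more of the compound is left, a lower number that less of the compound is left. In this assay compound 2 gives > 95%, which is a limit of the assay rather than a number. Compound 1, with the structure `C[C@@H](O)[C@H]1C(=O)N2C(C(=O)OCOC(=O)C3CCCCC3)=C(S[C@@H]3CN[C@H](C(=O)Nc4cccc(C(=O)O)c4)C3)[C@H](C)[C@H]12`, differs from compound 2 only at the carbonyl carbon, where it carries cyclohexyl in place of ethoxy. In this assay compound 1 gives > 95%, again a limit and not a number. The step that the two limits leave unreadable from compound 1 to compound 2 therefore cannot be read, since (the limit of > 95% in this assay, at which 2 of the 2 values shown sit).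

Compound 3, with the structure `C[C@@H](O)[C@H]1C(=O)N2C(C(=O)OCOC(=O)OC3CCCCC3)=C(S[C@@H]3CN[C@H](C(=O)Nc4cccc(C(=O)O)c4)C3)[C@H](C)[C@H]12`, is not yet measured. It differs from compound 2 by cyclohexyl in place of ethyl on an oxygen next to a carbonyl group. Among the compounds with values here, no measured step shows what this change does; the only step at hand, from compound 1 to compound 2, is unreadable, and both values so far sit at the same limit. Compound 3 is therefore expected to sit at the same limit, with a step that the limit leaves unreadable from compound 2 to compound 3 that is expected to be none beyond the scatter. The estimate for compound 3 in this assay is 96%, between 88% and 100%.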

Compound 3, percent of the compound remaining: > 95%
Compound 3: no number, only a limit (the forecaster's own chance of this, stated with the estimate: 75%); the middle value is on the limit's open side.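

In this assay compound 3 gives > 95%, which is a limit and not a number. No step between compound 3 and either compound 1 or compound 2 can therefore be read: the limit of > 95% in this assay, at which 3 of the 3 values shown sit.

The compounds shown leave open how these three truly rank in this assay, and whether any change in this part of the structure leaves less of the compound.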